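A Chloro Exchange on a Weakly Binding Oxazolidinone Series

The compounds below may be only part of what the source reports. "The series", "measured", "known", "first", "only" and "open" are said of these compounds alone.

Compound 2 `COCc1cccc(C[C@H](O)/C=C/[C@H]2COC(=O)N2CCSCCCC(=O)O)c1` was examined in an assay on CHO cells for displacement of a labelled ligand from prostaglandin E2 receptor EP3 subtype (Mus musculus), read by scintillation counting, with a stated time of 60 min; on this read-out higher numbers stand for weaker inhibition and lower numbers for stronger inhibition. There compound 2 reaches the assay limit of > 10000 nM, which is a limit and not a number. Its neighbour compound 1 `O=C(O)CCCSCCN1C(=O)OC[C@@H]1/C=C/[C@@H](O)Cc1cccc(-c2ccccc2)c1` carries a phenyl where compound 2 carries a methoxymethyl. In this assay compound 1 likewise gives the limit > 10000 nM. The step that the two limits leave unreadable from compound 1 to compound 2 therefore cannot be read, since the limit of > 10000 nM in this assay, at which 2 of the 2 values shown sit, holds both values. Compound 3 `O=C(O)CCCSCCN1C(=O)OC[C@@H]1/C=C/[C@@H](O)Cc1cccc(Cl)c1` differs from compound 2 by chloro in place of methoxymethyl on an aromatic carbon. Among the compounds with values here, no measured step bears on this exchange; the single step recorded is unreadable, so neither a size nor a direction in this assay can be drawn from it, and compound 3 may well sit at the same limit as compound 2. The step of a number no higher from compound 2 to compound 3 (the limit leaves the size open) is expected on that basis. Compound 3 is accordingly expected near 10000 nM, between 2000 nM and 50000 nM, in this assay.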

Compound 3, inhibition constant: 630 nM
For compound 3 the middle estimate is 16-fold (1.20 log units) above the measured one; measured number below the stated range.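

In this assay, replacing either larger group with chloro gives a clear change: an at least 15-fold lower number from compound 2 to compound 3 (1.20 log units; beyond the scatter), and an at least 15-fold lower number from compound 1 to compound 3 (1.20 log units; beyond the scatter). Within the data shown here, this shows that the group on this aromatic carbon, meta to a large group, can shift binding to a measurable level, and compound 3 is the first of the series to give a number rather than a limit. Neither step has an exact size, and the earlier step cannot be read because compound 1 and compound 2 share one limit: the limit of > 10000 nM in this assay, at which 2 of the 3 values shown sit.

Going by these compounds, it remains open whether bromo, fluoro, methyl or methoxy at this place would behave as chloro does. On these data alone, it is also open whether the chloro step would hold with a shorter or longer chain carrying the carboxylic acid.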